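Cyclohexyl Ester Lengthens Half-Life Across Two Cores

The source may hold more compounds than are shown below. What is called first, only, known or untested is meant among the compounds shown, and "the series" means these compounds.

Compound 1 `CCOC(=O)/C(C#N)=C/c1ccc(O)c(O)c1` and compound 2 `N#C/C(=C\c1ccc(O)c(O)c1)C(=O)OC1CCCCC1` share one core, while compound 3 `CCOC(=O)/C(C#N)=C/c1cc2ccccc2[nH]1` and compound 4 `N#C/C(=C\c1cc2ccccc2[nH]1)C(=O)OC1CCCCC1` share another; how the core of compound 3 differs from that of compound 1 is not broken down here. In an ADME assay on microsomes from liver (Rattus norvegicus) for metabolic stability, read by HPLC, using NADPH, tested at 40 mM, in the presence of a further agent that is not named here (on this read-out lower numbers stand for a shorter-lived compound and higher numbers for a longer-lived compound), compound 1 gives only a limit, < 0.0667 h. Compound 2, which carries cyclohexyl in place of ethyl on an oxygen next to a carbonyl group, gives 0.417 h in this assay. Within the data shown here, that measured step, an at least 6.2-fold higher number from compound 1 to compound 2 (0.79 log units; beyond the scatter), is the only measured instance of this change among the four compounds. Compound 3 likewise gives only a limit in this assay, < 0.0667 h. The change from compound 3 to compound 4, (cyclohexyl in place of ethyl on an oxygen next to a carbonyl group), is the same change made at a place described in the same words. Among the measured compounds shown here, compound 3 sits at the limit of < 0.0667 h in this assay, at which 2 of the 3 values shown sit, so its own value offers no step to read. The expected step of an at least 4.4-fold higher number from compound 3 to compound 4 (0.65 log units; beyond the scatter) therefore rests on the measured step of an at least 6.2-fold higher number from compound 1 to compound 2 (0.79 log units; beyond the scatter). Compound 4 is expected to give about 0.3 h in this assay. The estimate for compound 4 is put between 0.1 h and 0.8 h.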

Compound 4, half-life: 0.417 h
Estimate against measurement, compound 4: 1.4-fold (0.14 log units) below, within the range that was stated.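

In this assay, cyclohexyl in place of ethyl on an oxygen next to a carbonyl group gives an at least 6.2-fold higher number from compound 3 to compound 4 (0.79 log units; beyond the scatter), so the change carried over to the second core in the same direction. Set beside the earlier step, the two read as follows: the same change on two cores in this assay, an at least 6.2-fold higher number (0.79 log units; beyond the scatter) from compound 1 to compound 2 and an at least 6.2-fold higher number (0.79 log units; beyond the scatter) from compound 3 to compound 4; the limit leaves it open whether they differ. Both steps start from a limit of the assay and not from a number, so compound 1 and compound 3 show that the half-life rises on each core, but not by how much, and two cores do not make a rule for the whole series: the limit of < 0.0667 h in this assay, at which 2 of the 4 values shown sit.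

The compounds shown leave open whether the rise belongs to cyclohexyl itself or would also appear with a longer chain, a branched isopropyl or a phenyl ring on the same oxygen. They also leave open how an amide in place of the ester would behave, and what the change would do on any further core.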